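This account rests on a few compounds, and the source may have more. Where it says the series, first, only, none or still open, it means among the compounds named here.

Compound 1 `COCCOc1cc2oc(=O)n(CCC(=O)O)c2cc1Cl` — in an assay for inhibition of kynurenine 3-monooxygenase (Homo sapiens), read by mass spectrometry, with a stated time of 1 h (a higher number here means a weaker inhibitor, a lower number a stronger inhibitor), compound 1 gives 31.6 nM.
Compound 2 `CCc1cc2oc(=O)n(CCC(=O)O)c2cc1Cl` — in this assay compound 2 gives 10 nM.

Within the data shown here, of the two measured compounds, compound 2 carries the lower number; the nearest is compound 1, and the only measured step is a 3.2-fold lower number from compound 1 to compound 2 (0.50 log units; beyond the scatter), brought about by ethyl in place of 2-methoxyethoxy on an aromatic carbon.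

Compound 3 `O=C(O)CCn1c(=O)oc2cc(Cl)c(Cl)cc21` is the next compound, not yet measured. It differs from compound 2 by chloro in place of ethyl on an aromatic carbon of a six-membered aromatic ring of carbon only, part of a fused or bridged system of two rings, ortho to a chloro group, meta to a fused ring and para to a fused ring. Among the measured compounds shown here, the one measured step touches the same aromatic carbon and was modest, but no measured pair exchanges ethyl for chloro, so the direction of the new step cannot be taken from the data. A step in this assay close to the scatter is therefore expected, with a slight lean toward a higher number; the expected step is a 1.6-fold higher number from compound 2 to compound 3 (0.20 log units; within the scatter). For compound 3 the estimated value in this assay is 16 nM, expected to lie between 5 nM and 50 nM.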

Compound 3, half-maximal inhibitory concentration: 6.31 nM
The estimate for compound 3 lay 2.5-fold (0.40 log units) above the measured number; the measured number falls inside the stated range.
By their numbers in this assay, from the lowest: compounds 3 and 2 (each within the scatter of the next); then compound 1.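

At the aromatic carbon ortho to a chloro group, meta to a fused ring and para to a fused ring, the earlier compounds had shown only ethyl and 2-methoxyethoxy; exchanging ethyl for chloro gives a 1.6-fold lower number from compound 2 to compound 3 (0.20 log units; within the scatter) in this assay, so a single chlorine atom and the two carbons of ethyl are not told apart here. Chloro in place of 2-methoxyethoxy gives a 5.0-fold lower number from compound 1 to compound 3 (0.70 log units; beyond the scatter), which, with the earlier step, sets compound 1 apart from both compound 2 and compound 3 beyond the scatter, with the larger group carrying the higher number in both comparisons. Nothing available explains why these three groups compare as they do.

With only three groups at this carbon, the compounds shown leave open how a bromo group, a methoxy group or an amine would compare there. They also leave open whether a plain ethoxy group would match compound 1 or stand with compound 2 and compound 3, and so which part of the 2-methoxyethoxy chain goes with its higher number.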